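Methyl to Ethyl on the Anilide Ether

The source may report more compounds than this note shows. Statements on the series, on what has been measured and on what is new or still open speak of the compounds shown alone.

Among three pyrazole carboxanilides measured in a functional assay on MCF7 cells (Homo sapiens) for cytotoxicity, read by MTT assay, with a stated time of 48 h (on this read-out lower numbers stand for stronger inhibition and higher numbers for weaker inhibition), compound 3 `COc1ccc(NC(=O)c2cn(-c3ccccc3)nc2-c2ccc(OC)cc2)cc1` sits second highest with 1770 nM. Compound 1 `CCOc1ccc(NC(=O)c2cn(-c3ccccc3)nc2-c2ccc(C)cc2)cc1` gives 1030 nM, a number within the scatter of compound 3, while compound 2 `COc1ccc(-c2nn(-c3ccccc3)cc2C(=O)Nc2ccc(Br)cc2)cc1` gives 8210 nM. Among the compounds with values here, the only single-point step among them is a 4.6-fold lower number from compound 2 to compound 3 (0.67 log units; beyond the scatter), a change on the bromophenyl side of the amide rather than on the ether. Compound 4 `CCOc1ccc(NC(=O)c2cn(-c3ccccc3)nc2-c2ccc(OC)cc2)cc1` differs from compound 3 by methyl in place of hydrogen on a saturated chain carbon bound to an oxygen on an aromatic ring. Within the data shown here, no measured step bears directly on this change: compound 1 carries the ethoxy group but also differs from compound 3 on the other aryl ring, so its value and that of compound 3 only show two numbers within the scatter of each other. With nothing pointing to a shift, the step of a 1.3-fold lower number from compound 3 to compound 4 (0.10 log units; within the scatter) is expected to stay within the scatter. Compound 4 is therefore estimated at 1400 nM, with a range from 600 nM to 3500 nM.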

Compound 4, half-maximal inhibitory concentration: 1100 nM
Compound 4: middle estimate off by 1.3-fold (0.10 log units), on the high side, within the range that was stated.
By their numbers in this assay, from the lowest: compounds 1, 4 and 3 (each within the scatter of the next); then compound 2.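

In this assay, the change from 4-methoxyphenyl to 4-ethoxyphenyl gives a 1.6-fold lower number from compound 3 to compound 4 (0.21 log units; within the scatter) and thus shows directly that this added methyl brings no shift beyond the scatter. The lower number seen with methoxy in place of bromo also holds for the ethoxy group, with a 7.5-fold lower number from compound 2 to compound 4 (0.87 log units; beyond the scatter) when ethoxy replaces the bromo group. With the ethoxy group present, a methoxy group taking the place of the methyl group gives a 1.1-fold higher number from compound 1 to compound 4 (0.03 log units; within the scatter) and so also stays within the scatter.

Going by these compounds, whether a longer chain such as propoxy, or an amine in place of the ether, would stay within the scatter of compound 3 remains open. Nothing given here offers an explanation for these numbers.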